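The source may report more compounds than this note shows. Statements on the series, on what has been measured and on what is new or still open speak of the compounds shown alone.

Values measured in a functional assay on A549 cells (Homo sapiens) for inhibition, read by CCK-8 assay, with a stated time of 48 h; a higher number here means a weaker inhibitor, a lower number a stronger inhibitor:

- Compound 1 `COc1cc(-c2ccnc3cc(-c4ccc(F)cc4)nn23)cc(OC)c1OC`: 3800 nM
- Compound 2 `COc1cc(-c2ccnc3cc(-c4c[nH]c5ccccc45)nn23)cc(OC)c1OC`: 29 nM
- Compound 3 `COc1cc(-c2ccnc3cc(-c4cccc(C#N)c4)nn23)cc(OC)c1OC`: > 10000 nM

Compound 3 stands at > 10000 nM, which is a limit of the assay and not a number. It is the only one of the three without a measured value, and every step that involves it is therefore open-ended.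

The next compound is compound 4 `COc1cc(-c2ccnc3cc(-c4ccc5c(ccn5C)c4)nn23)cc(OC)c1OC`, which keeps the shared core and changes one group: 1-methyl-1H-indol-5-yl in place of 3-cyanophenyl on an aromatic carbon. In words, 1-methyl-1H-indol-5-yl replaces 3-cyanophenyl on an aromatic carbon.

Three measured steps change the same place. Two of them are large and favour the indole of compound 2: a 130-fold lower number from compound 1 to compound 2 (2.12 log units; beyond the scatter), and an at least 340-fold higher number from compound 2 to compound 3 (2.53 log units; beyond the scatter). The third, an at least 2.6-fold higher number from compound 1 to compound 3 (0.42 log units; beyond the scatter), is at least modest. Compound 2 is the strongest of the three in this assay, but it carries 1H-indol-3-yl rather than the group of compound 4, so it is only a partial guide, and the expected range is kept wide.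

With compound 2 at 29 nM, a large move to a lower number is expected, estimated as an at least 120-fold lower number from compound 3 to compound 4 (2.09 log units; beyond the scatter). The expected value for compound 4 is 80 nM. The estimated range for compound 4 runs from 10 nM to 1000 nM.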

Compound 4, half-maximal inhibitory concentration: 15 nM
Beside the measured number, compound 4's estimate is 5.3-fold (0.73 log units) above it, within the range that was stated.
By their numbers in this assay, from the lowest: compounds 4 and 2 (each within the scatter of the next); then compound 1. At a limit, above all of these: compound 3.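

Within this assay, this position is not tied to one form of indole: 1-methyl-1H-indol-5-yl and 1H-indol-3-yl cannot be told apart, with a 1.9-fold lower number from compound 2 to compound 4 (0.29 log units; within the scatter), so the earlier result for compound 2 was not unique to its group. The two indole-bearing compounds are also clearly separated from the two bearing a substituted phenyl, with a 250-fold lower number from compound 1 to compound 4 (2.40 log units; beyond the scatter) and an at least 660-fold lower number from compound 3 to compound 4 (2.82 log units; beyond the scatter), and among the compounds shown no indole falls on the weak side and no substituted phenyl on the strong side. The value of compound 3 is a limit of the assay and not a number, which leaves the second of those steps open-ended: the limit of > 10000 nM in this assay, at which 1 of the 4 values shown sits.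

Compound 2 and compound 4 differ both in the methyl on the indole nitrogen and in the point of attachment, and the effects of the two remain unseparated; a 1H-indol-5-yl or a 1-methyl-1H-indol-3-yl group in the same place would divide them. On these data alone, whether the indole nitrogen itself matters also remains open, a question that a naphthyl or a benzofuranyl group at this position would address.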